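Replacing a Chlorophenylethyl Arm with a Phenylethynyl Arm

The compounds below may be only part of what the source reports. "The series", "measured", "known", "first", "only" and "open" are said of these compounds alone.

The measured compounds are these. Compound 1 `COc1ccc(CCCN2CCC(CO)CC2)cc1` gives in a functional assay on cells (T-cell line, Homo sapiens) for inhibition (on this read-out higher numbers stand for weaker inhibition and lower numbers for stronger inhibition), only a limit of the assay, > 20000 nM. Compound 2 `COc1ccc(CCCN2CCC(C(O)CC(c3ccccc3)c3ccccc3)CC2)cc1` gives 1500 nM. Compound 3 `Clc1ccccc1CCCN1CCC(COC(c2ccccc2)c2ccccc2)CC1` gives 800 nM.

Of the three, only compound 2 and compound 3 have a number rather than a limit, and the two numbers lie within the scatter of each other, so neither can be ranked against the other. Compound 1 stands apart with its limit (the limit of > 20000 nM in this assay, at which 1 of the 3 values shown sits). Going by the values given here, no pair among the measured compounds differs in one place, so no measured step is available.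

Compound 4 `C(#Cc1ccccc1)CN1CCC(COC(c2ccccc2)c2ccccc2)CC1` has not yet been measured. It differs from compound 3 in one place: 2-phenylethynyl in place of 2-(2-chlorophenyl)ethyl on a saturated chain carbon bound to an amine nitrogen in a ring. Among the compounds with values here, nothing among the measured compounds shows what such an exchange does in this assay, so the expectation rests only on the structural change itself and carries a wide range. The step of a 2.3-fold higher number from compound 3 to compound 4 (0.35 log units; beyond the scatter) is expected to be a modest rise in the number, somewhat beyond the scatter. Compound 4 is thus estimated at 1800 nM, with a range from 400 nM to 8000 nM.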

Compound 4, half-maximal inhibitory concentration: > 20000 nM
Compound 4 gave a limit, no number (the forecaster's own chance of this, stated with the estimate: 10%); middle value at least 11-fold (1.04 log units) away from the limit.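

In this assay, replacing 2-(2-chlorophenyl)ethyl with 2-phenylethynyl on a saturated chain carbon bound to an amine nitrogen in a ring gives an at least 25-fold higher number from compound 3 to compound 4 (1.39 log units; beyond the scatter). Going by these compounds alone, this is the first single change measured, and it shows that this place is not indifferent to what it carries: with the rest of the structure held the same, the measurable inhibition of compound 3 gives way to no measurable number at all. Compound 4 gives a limit of the assay, not a number, so this step has a lower bound and no exact size: the limit of > 20000 nM in this assay, at which 2 of the 4 values shown sit.

The exchange removes the chlorine and brings in the triple bond in a single step, and the compounds shown do not tell which of the two goes with the loss, or whether both do. A 3-phenylpropyl arm, which has no chlorine and no triple bond, and a 3-(2-chlorophenyl)prop-2-yn-1-yl arm, which has both, would separate these two parts of the change on the same core.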